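A few compounds are considered here, and "the series" means these few. Any claim that something is new, unique, unknown or untested is made for them only; others in the source may bear on it.

The shared core of these compounds, seen in compound 1 `ClCc1ccccc1Cn1cnc2c(Cl)nc(Cl)nc21`, carries a chloro group on the aromatic carbon that compound 2 `ClCc1ccccc1Cn1cnc2c(Cl)ncnc21` leaves as hydrogen, while compound 3 `ClCc1cccc(Cn2cnc3c(Cl)ncnc32)c1` differs from compound 2 only in the benzyl portion. In a functional assay on SF-539 cells (Homo sapiens) for cytotoxicity, read by sulforhodamine B assay, with a stated time of 48 h (a lower number here means a stronger inhibitor of growth, a higher number a weaker inhibitor of growth), compound 1 gives 2880 nM, compound 2 gives 24000 nM, and compound 3 gives 35500 nM. Compound 2 therefore stands second highest of the three numbers: its gap to compound 3 lies within the scatter, whereas an 8.3-fold higher number from compound 1 to compound 2 (0.92 log units; beyond the scatter) lies beyond it.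

Compound 4 `Nc1nc(Cl)c2ncn(Cc3ccccc3CCl)c2n1` arises from compound 2 by amino in place of hydrogen on an aromatic carbon. Among the measured compounds shown here, this is the same aromatic carbon at which compound 1 and compound 2 differ, so the one measured step that bears on the change is an 8.3-fold higher number from compound 1 to compound 2 (0.92 log units; beyond the scatter), a modest step which shows that substitution at this carbon moves the number. For the measured compounds named here, no measured pair shows an amino group entering, so the direction for compound 4 cannot be read from the data, and a step of modest size either way would be consistent with what is known. The account therefore expects for compound 4 in this assay a value of 10000 nM, within a range from 2500 nM to 40000 nM, which is expected to mean a step of a 2.4-fold lower number from compound 2 to compound 4 (0.38 log units; beyond the scatter).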

Compound 4, concentration for total growth inhibition: 38000 nM
For compound 4 the middle estimate is 3.8-fold (0.58 log units) below the measured one; the range from low to high includes it.
By their numbers in this assay, from the lowest: compound 1; then compounds 2, 3 and 4 (each within the scatter of the next).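

In this assay, amino in place of hydrogen on the aromatic carbon between two ring nitrogen atoms gives a 1.6-fold higher number from compound 2 to compound 4 (0.20 log units; within the scatter) and so does not separate the two groups, although the earlier compounds had shown only that this carbon responds to a chloro group. Amino in place of chloro at the same carbon gives a 13-fold higher number from compound 1 to compound 4 (1.12 log units; beyond the scatter) and is a large step, which sets compound 1 apart from both compound 2 and compound 4. Among these three compounds, the difference at this carbon therefore lies with the chloro group, not with any departure from hydrogen, and nothing shown accounts for why this is so.

The compounds shown leave open whether a bromo, fluoro or methyl group on this carbon would stay with chloro or fall with hydrogen and amino, and whether a larger amine such as dimethylamino would behave as amino does. They also leave open whether the change in the benzyl portion seen in compound 3, which carries hydrogen on this carbon, would matter with chloro or amino there.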